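The compounds below may be only part of what the source reports. "The series", "measured", "known", "first", "only" and "open" are said of these compounds alone.

Of the compounds shown here, three sharing one core have been tested in an assay on CHO cells for displacement of a labelled ligand from adenosine receptor A1 (Homo sapiens), read by scintillation counting, with a stated time of 120 min, tested at 1 uM; on this read-out lower numbers stand for less inhibition and higher numbers for more inhibition at the one concentration tested (going by the name of the read-out). Compound 1 `Cc1nc(NC(=O)NCc2ccccc2)c2nn(-c3ccccc3)cc2n1` gives 26% in this assay, the highest of the three numbers. Compound 2 `COc1ccc(-n2cc3nc(-c4ccccc4)nc(N)c3n2)cc1` gives 12%, and compound 3 `COc1ccc(-n2cc3nc(C)nc(NC(=O)NCc4ccccc4)c3n2)cc1` gives 8%, both beyond the scatter below compound 1. Among the compounds with values here, the only single-point step among them, a number 18 percentage points lower from compound 1 to compound 3 (beyond the scatter), concerns a methoxy in place of hydrogen on an aromatic carbon. Compound 4 `Cc1nc(NC(=O)c2ccco2)c2nn(-c3ccccc3)cc2n1` differs from compound 1 in a different way: furan-2-yl in place of benzylamino on a carbonyl carbon. Within the data shown here, no measured step touches this change, so the measured compounds give no direction for it. Compound 4 is therefore expected to stay near that level, with a number 6 percentage points lower from compound 1 to compound 4 (within the scatter) within the scatter. The estimate for compound 4 is 20%, with a range from 5% to 40%.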

Compound 4, a percentage reported as inhibition, at one concentration (the size of the read-out at that concentration, not a potency): 20%
Beside the measured number, compound 4's estimate shows no gap at the digits printed; the measured number falls inside the stated range.
By their numbers in this assay, from the lowest: compounds 3, 2, 4 and 1 (each within the scatter of the next, the first and the last beyond it).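

In this assay, within the data shown here, the first step at this carbonyl carbon, furan-2-yl in place of benzylamino, gives a number 6 percentage points lower from compound 1 to compound 4 (within the scatter). At this single concentration, the benzylamino group, with its six-membered aromatic ring and hydrogen-bond donor, can therefore give way to furan-2-yl without a shift beyond the scatter. Nothing available bears on the reason for this result. Still open, going by these compounds, is how a longer chain such as phenethylamino, or a simple amine such as dimethylamino, would read on the same carbonyl carbon. Also open, on these data alone, is whether methoxy would give a comparable step alongside furan-2-yl.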